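The compounds below may be only part of what the source reports. "The series", "measured", "known", "first", "only" and "open" are said of these compounds alone.

For the measured compounds named here, compound 2, with the structure `C/C(=N\NC(=O)COc1cccc2ccccc12)c1ccccc1O`, is one of two compounds measured so far in an ADME assay on HEL cells (Homo sapiens) for cytotoxicity; on this read-out higher numbers stand for lower toxicity in this test and lower numbers for higher toxicity in this test. In this assay compound 2 gives 20 ug/mL. Its nearest neighbour is compound 1, whose structure is `C/C(=N\NC(=O)COc1cccc2ccccc12)c1ccc(O)cc1`; in this assay compound 1 gives 20 ug/mL. The two share the same core and differ only in where the hydroxy sits: the step from compound 1 to compound 2 reads no change at the digits printed from compound 1 to compound 2 (within the scatter), so moving the hydroxy around the ring left the read-out where it was.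

The next compound, compound 3, has the structure `C/C(=N\NC(=O)COc1cccc2ccccc12)c1ccccc1` and has not been measured in this assay. Compared with compound 2 the change is hydrogen in place of hydroxy on an aromatic carbon.

Going by the values given here, no measured step removes a hydroxy altogether; the only step available, from compound 1 to compound 2, is a relocation of that group and lies within the scatter. With so little to go on, the expected step from compound 2 to compound 3 is no change at the digits printed from compound 2 to compound 3 (within the scatter), that is, no change beyond the scatter. Compound 3 is therefore estimated at 20 ug/mL, with a range from 10 ug/mL to 40 ug/mL.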

Compound 3, minimum cytotoxic concentration in the HEL assay: 20 ug/mL
For compound 3 middle estimate and measured number coincide at the digits printed, within the range that was stated.
By their numbers in the HEL assay, from the lowest: compounds 1, 2 and 3 (each within the scatter of the next).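

In the HEL assay, removing the hydroxy altogether changes nothing that the relocation had not already left untouched: the 2-hydroxyphenyl to phenyl change reads no change at the digits printed from compound 2 to compound 3 (within the scatter), and the same removal from the 4-hydroxyphenyl compound reads no change at the digits printed from compound 1 to compound 3 (within the scatter). This read-out therefore does not depend on a hydroxy being present on this ring, at either of the two places shown. The change is not silent in every measurement, however, since in a physicochemical assay for lipophilicity, measured as octanol-water partition (on this read-out lower numbers stand for lower lipophilicity and higher numbers for higher lipophilicity), compound 2 gives 3.08 and compound 3 gives 3.65, so hydrogen in place of hydroxy shifts lipophilicity while the cytotoxicity read-out stays level: the measured partition coefficient of compound 2, 3.08, and of compound 3, 3.65, a number 0.57 log units higher (beyond the scatter)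

Only hydroxy and hydrogen are shown at this place, so it stays open whether a larger or charged group, such as a methoxy group, an amine or a carboxylic acid, would also leave the cytotoxicity read-out level. On these data alone, it is equally open whether a change elsewhere on the shared core, such as a longer chain, would leave it level.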